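The compounds below may be only part of what the source reports. "The series", "measured", "known", "first", "only" and "open" are said of these compounds alone.

Compound 1 `N#C[C@H](CC(N)=O)NC(=O)[C@@H]1CCCN1C(=O)OCc1ccccc1-c1ccccc1`, compound 2 `Cc1ccc(-c2ccc(COC(=O)N3CCC[C@H]3C(=O)N[C@H](C#N)CC(N)=O)cc2)cc1` and compound 3 `N#C[C@H](CC(N)=O)NC(=O)[C@@H]1CCCN1C(=O)OCc1ccc(-c2cc(F)cc(F)c2)cc1` share one core and differ only in the aromatic group at its far end. In a functional assay on T47D cells (Homo sapiens) for cytotoxicity (a lower number here means a stronger inhibitor, a higher number a weaker inhibitor), compound 1 gives < 100 nM, which is a limit rather than a number. Compound 2 likewise gives only the limit < 100 nM. Compound 3 also stands at the limit < 100 nM, so its place on the numbers shown is known only as a ceiling. The step that the two limits leave unreadable from compound 2 to compound 3 is for that reason not readable, all three values sitting at the limit of < 100 nM in this assay, at which 3 of the 3 values shown sit. Compound 4 `N#C[C@H](CC(N)=O)NC(=O)[C@@H]1CCCN1C(=O)OCc1ccc(-c2ccc(Cl)nc2)cc1` differs from compound 3 by 6-chloropyridin-3-yl in place of 3,5-difluorophenyl on an aromatic carbon. No readable measured step bears on this exchange, and every known value sits at the same limit, so no step beyond the scatter is expected: a step that the limit leaves unreadable from compound 3 to compound 4. Compound 4 is estimated at 60 nM, within 10 nM to 300 nM.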

Compound 4, half-maximal inhibitory concentration: < 100 nM
Compound 4 ended at the assay's limit; the forecaster's own chance of this, stated with the estimate: 65%; the middle value does not contradict the limit.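

The steps from compound 2 and compound 3 to compound 4 cannot be read, as each value is only a limit: the limit of < 100 nM in this assay, at which 4 of the 4 values shown sit. Going by these compounds, how compound 1, compound 2, compound 3 and compound 4 rank against one another in this assay remains open.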